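The source may hold more compounds than are shown below. What is called first, only, known or untested is meant among the compounds shown, and "the series" means these compounds.

Compound 1 `CS(=O)(=O)c1ccc(-c2oc3ccccc3c(=O)c2-c2ccc(F)cc2)cc1` gives < 8% in an assay on isolated protein for inhibition of prostaglandin G/H synthase 1 (Mus musculus), tested at 10 ug/mL (on this read-out higher numbers stand for more inhibition at the one concentration tested (going by the name of the read-out) and lower numbers for less inhibition), which is a limit of the assay.
Compound 2 `CS(=O)(=O)c1ccc(-c2oc3ccccc3c(=O)c2-c2cccc(Cl)c2)cc1` gives < 5% in this assay, again a limit of the assay.
Compound 3 `CS(=O)(=O)c1ccc(-c2oc3ccccc3c(=O)c2-c2ccc(Cl)cc2)cc1` gives < 5% in this assay, also a limit of the assay.

Compound 3 thus stands only at a limit in this assay, and so do its two neighbours. For the measured compounds named here, because of the limit of < 5% in this assay, at which 2 of the 3 values shown sit, and (the limit of < 8% in this assay, at which 1 of the 3 values shown sits), none of the measured steps can be read: a step that the two limits leave unreadable from compound 1 to compound 2, a step that the two limits leave unreadable from compound 1 to compound 3 and a step that the two limits leave unreadable from compound 2 to compound 3 all stay hidden behind the limits. The change to compound 4 `Cn1cc(-c2c(-c3ccc(S(C)(=O)=O)cc3)oc3ccccc3c2=O)cn1` is 1-methyl-1H-pyrazol-4-yl in place of 4-chlorophenyl on an aromatic carbon. Going by the values given here, no measured step bears on this change in a readable way; what the three measured compounds show is only that this shared core, with three different aryl groups in that place, has so far stayed at the limits of this assay. On that basis compound 4 is expected to stay low as well, most likely again as a limit. Compound 4 is estimated at 5%, with a range from 0% to 15%. The expected step is a number no lower from compound 3 to compound 4 (the limit leaves the size open), nothing beyond the scatter.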

Compound 4, a percentage reported as inhibition, at one concentration (the size of the read-out at that concentration, not a potency): < 5%
Compound 4 ended at the assay's limit; the forecaster's own chance of this, stated with the estimate: 65%; the middle value lies on the limit itself.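

Compound 4 also sits at a limit in this assay, so its steps from compound 1, compound 2 and compound 3 cannot be read, because all four values are limits, most of them the same one: the limit of < 5% in this assay, at which 3 of the 4 values shown sit.

The compounds shown leave open whether any group in that place on the shared core gives a readable inhibition in this assay.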